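The source may hold more compounds than are shown below. What is called first, only, known or untested is meant among the compounds shown, and "the series" means these compounds.

Measured so far:
- compound 1 `CC(=O)Nc1nc(-c2cccc(NS(=O)(=O)c3ccc(Br)cc3)c2)cs1`: "not active" (no number reported)
- compound 2 `CCCCCCCCC#Cc1ccc(S(=O)(=O)Nc2cccc(-c3csc(NC(C)=O)n3)c2)cc1`: 39.6%

In a functional assay on A-375 cells (Homo sapiens) for antiproliferative activity, read by trypan blue exclusion, with a stated time of 48 h, tested at 1 uM (on this read-out higher numbers stand for a weaker effect at the one concentration tested and lower numbers for a stronger effect), compound 1 is reported as "not active" (no number reported) and carries no number. Among the compounds with values here, compound 2 gives 39.6% in this assay and is the only compound of the series with a number, so it has no neighbour to be placed against. Compound 3 `CCCCCCCCc1ccc(S(=O)(=O)Nc2cccc(-c3csc(NC(C)=O)n3)c2)cc1` differs from compound 2 by one change: octyl in place of dec-1-yn-1-yl on an aromatic carbon. Within the data shown here, no step between two measured compounds is available to gauge the size of such a change. The expected step from compound 2 to compound 3 is a number 10.4 percentage points higher from compound 2 to compound 3 (beyond the scatter), a modest shift toward a weaker effect, close to the scatter. For compound 3 the estimate in this assay is 50%, within 30% to 75%.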

Compound 3, a percentage reported as activity, at one concentration (the size of the read-out at that concentration, not a potency): 34.8%
For compound 3 the middle estimate is 15.2 percentage points above the measured one; the measured number falls inside the stated range.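

In this assay the first step read at this position is a number 4.8 percentage points lower from compound 2 to compound 3 (within the scatter), so the two chains on the aromatic carbon stand within the scatter of each other. On this one pair, a triple bond outside aromatic rings is not needed for a number at this level. No measured evidence bears on this result. Going by these compounds, whether a longer chain, or an octyl chain ending in an amine or a carboxylic acid, stays at this level remains open. Also open, on these data alone, is how much chain length separates these two compounds from compound 1 , reported as "not active" (no number reported).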